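The compounds below may be only part of what the source reports. "The series", "measured", "known", "first", "only" and "open" are said of these compounds alone.

Measured compounds:
- Compound 1, `CCCCCCN1CCC(C(=O)Nc2cc(Cl)c(N)cc2OC)CC1`: > 10 mg/kg
- Compound 2, `COc1ccc(CN2CCC(C(=O)Nc3cc(Cl)c(N)cc3OC)CC2)cc1`: 0.9 mg/kg
- Compound 3, `CCCCCN1CCC(C(=O)Nc2cc(Cl)c(N)cc2OC)CC1`: > 10 mg/kg

All three share one core and differ only in the group on the ring nitrogen. In a functional assay on the whole organism for antagonist activity, with Mus musculus as the target (on this read-out higher numbers stand for an effect only at larger amounts of compound and lower numbers for an effect already at smaller amounts), compound 1 gives > 10 mg/kg, which is a limit of the assay and not a measured number. Compound 3 likewise gives > 10 mg/kg, again only a limit. Compound 2 gives 0.9 mg/kg, a real number. So an at least 11-fold lower number from compound 1 to compound 2 (1.04 log units; beyond the scatter), and an at least 11-fold higher number from compound 2 to compound 3 (1.04 log units; beyond the scatter), whereas a step that the two limits leave unreadable from compound 1 to compound 3.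

The unmeasured compound 4, `CCN1CCC(C(=O)Nc2cc(Cl)c(N)cc2OC)CC1`, keeps a plain chain but shortens it: hydrogen in place of butyl on a saturated chain carbon, two bonds along the chain from an amine nitrogen in a ring. Going by the values given here, the one measured step along such a chain, from compound 1 to compound 3, gives no direction, since both values sit at the limit of > 10 mg/kg in this assay, at which 2 of the 3 values shown sit. Nothing here shows that a shorter chain behaves differently from a longer one. Compound 4 is therefore expected to stay at or near that limit, with an estimate of 15 mg/kg, spanning 5 mg/kg to 50 mg/kg. The expected step is a step that the limit leaves unreadable from compound 1 to compound 4, most likely again unreadable against a limit.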

Compound 4, dose for half-maximal effect: > 10 mg/kg
Compound 4 ended at the assay's limit; the forecaster's own chance of this, stated with the estimate: 70%; the middle value lies beyond the limit too.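

In this assay compound 4 gives > 10 mg/kg, a limit and not a number. With ethyl on the ring nitrogen, the short chain joins hexyl and pentyl at the same limit, and the steps among these three cannot be read: the limit of > 10 mg/kg in this assay, at which 3 of the 4 values shown sit. Going by these compounds alone, the one step that can be read is an at least 11-fold higher number from compound 2 to compound 4 (1.04 log units; beyond the scatter), so shortening the plain chain to ethyl does not bring back the effect seen with the 4-methoxyphenyl group on that chain carbon.

From the compounds shown here alone, how far that effect rests on the ring and how far on its methoxy stays open, and a plain benzyl group on the ring nitrogen would separate the two. Whether the plain chains differ at all stays hidden behind the limit, and a chain ending in an amine or a hydroxyl group might or might not come in under it.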